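Swapping a methoxy for a benzothiophene: cytotoxicity outlook

The compounds below may be only part of what the source reports. "The series", "measured", "known", "first", "only" and "open" are said of these compounds alone.

Measured compounds and their values:
- compound 1, `CCC(CC)O[C@@H]1C=C(C(=O)O)C[C@H](NCc2ccc(OC)cc2)[C@H]1NC(C)=O`: > 200000 nM
- compound 2, `CCC(CC)O[C@@H]1C=C(C(=O)O)C[C@H](NCc2ccc(OC(C)C)cc2)[C@H]1NC(C)=O`: > 200000 nM
- compound 3, `CCC(CC)Oc1ccc(CN[C@H]2CC(C(=O)O)=C[C@@H](OC(CC)CC)[C@@H]2NC(C)=O)cc1`: > 200000 nM

In an ADME assay on cells (Fibroblast, Gallus gallus) for cytotoxicity, read by CCK-8 assay, with a stated time of 48 h (on this read-out lower numbers stand for higher toxicity in this test and higher numbers for lower toxicity in this test), compound 1 gives > 200000 nM, which is a limit of the test and not a number. Compound 2 also reaches a limit there. So does compound 3. The steps a step that the two limits leave unreadable from compound 1 to compound 2 and a step that the two limits leave unreadable from compound 1 to compound 3 therefore cannot be read in size, because of the limit of > 200000 nM in this assay, at which 3 of the 3 values shown sit; compound 1 stands at that same limit, alongside the other two.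

Compound 4, `CCC(CC)O[C@@H]1C=C(C(=O)O)C[C@H](NCc2ccc(-c3csc4ccccc34)cc2)[C@H]1NC(C)=O`, differs from compound 1 in one place: 1-benzothiophen-3-yl in place of methoxy on an aromatic carbon. The methoxy leaves and a 1-benzothiophen-3-yl enters, on an aromatic carbon of a six-membered aromatic ring of carbon only, para to a large group. The measured steps, which only enlarge the group on the oxygen, all stay at the limit and give no readable size, so they offer no direction for this larger change; they suggest the series is tolerated by the cells so far.

Compound 4 is therefore expected to sit near the same limit in this assay, with the step of a number no higher from compound 1 to compound 4 (the limit leaves the size open) expected to be small or unreadable. The estimate for compound 4 is 200000 nM, between 50000 nM and 500000 nM.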

Compound 4, half-maximal cytotoxic concentration: > 200000 nM
Compound 4 was reported as a limit; the forecaster's own chance of this, stated with the estimate: 65%; the middle value lies on the limit itself.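

In this assay compound 4 gives > 200000 nM, which is a limit and not a number. No step linking compound 4 with compound 1, compound 2 or compound 3 can be read in size, because all four compounds stand at the same limit: the limit of > 200000 nM in this assay, at which 4 of the 4 values shown sit.

The compounds shown leave open at what concentration any of them would become toxic to these cells, and whether 1-benzothiophen-3-yl in place of methoxy shifts that concentration.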